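Bromo to chloro on the fused ring of compound 1

The source may hold more compounds than are shown below. What is called first, only, known or untested is meant among the compounds shown, and "the series" means these compounds.

Measured compounds:
compound 1, `O=C1N=C(N2N=C(c3ccc(Cl)cc3)CC2c2ccc(Cl)cc2)S/C1=C1\C(=O)Nc2ccc(Br)cc21`, 730 nM
compound 2, `O=C1N=C(N2N=C(c3ccccc3)CC2c2ccc(Cl)cc2)S/C1=C1\C(=O)Nc2ccccc21`, "not determined" (no result reported)

Among the compounds with values here, compound 1 is the only compound of this set with a number in a functional assay on Mino cells (Homo sapiens) for cytotoxicity, read by MTT assay, with a stated time of 72 h; a lower number here means a stronger inhibitor, a higher number a weaker inhibitor; compound 2 was examined in the same study but gives only "not determined" (no result reported) there, so compound 1 stands alone and cannot be ranked against anything. In this assay compound 1 gives 730 nM.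

The untested compound 3 is `O=C1N=C(N2N=C(c3ccc(Cl)cc3)CC2c2ccc(Cl)cc2)S/C1=C1\C(=O)Nc2ccc(Cl)cc21`. It differs from compound 1 in a single place: chloro in place of bromo on an aromatic carbon. Within the data shown here, no step between two measured compounds is available to guide this exchange of one halogen for another. On the shared core, such an exchange is expected to move the half-maximal inhibitory concentration by no more than the usual scatter of repeated measurements, in no clear direction.

Compound 3 is therefore expected to show a step of a 1.1-fold higher number from compound 1 to compound 3 (0.04 log units; within the scatter) in this assay. The estimate for compound 3 is 800 nM, with a range from 350 nM to 1800 nM.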

Compound 3, half-maximal inhibitory concentration: 80700 nM
For compound 3 the middle estimate is 100-fold (2.00 log units) below the measured one, and the stated range ends below it.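

In this assay, chloro in place of bromo on this aromatic carbon is far from a neutral exchange of one halogen for another: it brings a 110-fold higher number from compound 1 to compound 3 (2.04 log units; beyond the scatter). Within the data shown here, the read-out on the shared core therefore depends strongly on which halogen sits at this place in the fused system of two rings, something that compound 1, as the only earlier number, could not show. Nothing given here accounts for the size of this step.

The compounds shown leave open what fluoro, iodo, methoxy or an amine on this aromatic carbon would give, and so whether the number of compound 1 is particular to bromo. They also leave open whether the same exchange would give a step of this size with different groups elsewhere on the core.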